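A methyl added beside a urea stereocentre

This account rests on a few compounds, and the source may have more. Where it says the series, first, only, none or still open, it means among the compounds named here.

Compound 2 `Cc1cccc(NC(=O)N[C@@H](C)c2ccccc2)c1` gives 99% in an ADME assay on the whole organism with Oryza sativa as the target, tested at 0.1 uM (on this read-out higher numbers stand for a weaker effect at the one concentration tested and lower numbers for a stronger effect), and compound 1 `Cc1cccc(NC(=O)N[C@H](C)c2ccccc2)c1` gives 100% in this assay; the two stand together within the scatter, the step of a number 1 percentage points lower from compound 1 to compound 2 (within the scatter) resting only on (the fact that compounds 1 and 2 differ only in the configuration as drawn). Compound 3 `CCc1cccc(NC(=O)N[C@@H](C)c2ccccc2)c1` differs from compound 2 by methyl in place of hydrogen on a saturated chain carbon bound to an aromatic carbon. Among the measured compounds shown here, the single measured step, from compound 1 to compound 2, concerns configuration alone and carries no information about this change, so no movement beyond the scatter is expected in this assay. Compound 3 is therefore estimated at 97%, between 85% and 100%, an expected step of a number 2 percentage points lower from compound 2 to compound 3 (within the scatter).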

Compound 3, a percentage reported as activity, at one concentration (the size of the read-out at that concentration, not a potency): 100%
For compound 3 the middle estimate is 3 percentage points below the measured one; low and high end bracket the measured number.
By their numbers in this assay, from the lowest: compounds 2, 1 and 3 (each within the scatter of the next).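

In this assay, among the compounds shown here, the change from methyl to ethyl gives a number 1 percentage points higher from compound 2 to compound 3 (within the scatter) and so adds the first reading on a change of group, which the pair differing only in configuration could not supply. On a saturated chain carbon bound to an aromatic carbon, ethyl therefore leaves the number within the scatter of the methyl compound.

On these data alone, whether a longer chain such as propyl, or an amine or a carboxylic acid, would leave the number equally unmoved stays open, as does the behaviour of ethyl in the opposite configuration. Nothing given here bears on the cause of this result.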